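Swapping a Chloro Aryl Ring for a Hydroxy Aryl Ring

This account rests on a few compounds, and the source may have more. Where it says the series, first, only, none or still open, it means among the compounds named here.

Compound 1 `Clc1cccc(-c2nc(N3CCCCC3)c3nc[nH]c3n2)c1` was tested in an assay on cells for displacement of a labelled ligand from adenosine receptor A2b (Homo sapiens), read by scintillation counting and radioligand binding, with a stated time of 30 min, tested at 10 uM; a higher number here means more inhibition at the concentration tested (going by the name of the read-out), a lower number less inhibition. In this assay compound 1 gives > 80%, a value that is a limit of the assay rather than a number. Compound 1 therefore sits at the limit of > 80% in this assay, at which 1 of the 3 values shown sits. Two changes from it have been measured. Compound 2 `CN1CCN(c2nc(-c3cccc(Cl)c3)nc3[nH]cnc23)CC1` gives 29.9%, so that a number at least 50.1 percentage points lower from compound 1 to compound 2 (beyond the scatter). Compound 3 `Clc1ccc(-c2nc(N3CCCCC3)c3nc[nH]c3n2)cc1Cl` gives 0.7%, so that a number at least 79.3 percentage points lower from compound 1 to compound 3 (beyond the scatter). Compound 4 `Oc1ccc(-c2nc(N3CCCCC3)c3nc[nH]c3n2)cc1` has not yet been measured; it differs from compound 1 by 4-hydroxyphenyl in place of 3-chlorophenyl on an aromatic carbon. The change to compound 3 also touched the aryl ring and lost nearly all inhibition, so a drop is expected here too. The estimated value for compound 4 is 35%, between 5% and 75%. This expectation corresponds to a number at least 45 percentage points lower from compound 1 to compound 4 (beyond the scatter).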

Compound 4, a percentage reported as inhibition, at one concentration (the size of the read-out at that concentration, not a potency): > 80%
Compound 4: only a limit was reported; the forecaster's own chance of this, stated with the estimate: 0.1%; at least 45 percentage points between middle value and limit.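

Compound 1 and compound 4 both carry a limit rather than a number, so no step between them can be read: the limit of > 80% in this assay, at which 2 of the 4 values shown sit.

From the compounds shown here alone, whether 4-hydroxyphenyl or 3-chlorophenyl gives more inhibition in this assay stays open.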